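Moving from pyridin-4-yl to pyridin-3-yl

The source may report more compounds than this note shows. Statements on the series, on what has been measured and on what is new or still open speak of the compounds shown alone.

Measured in a functional assay on KB cells (Homo sapiens) for inhibition, with a stated time of 72 h; a higher number here means a weaker inhibitor, a lower number a stronger inhibitor:
- compound 1 `COc1ccc(S(=O)(=O)N2CCc3cccc(-c4ccc(F)nc4)c32)cc1`: 143 nM
- compound 2 `COc1ccc(S(=O)(=O)N2CCc3cccc(-c4ccc(F)cc4)c32)cc1`: 86 nM
- compound 3 `COc1ccc(S(=O)(=O)N2CCc3cccc(-c4ccncc4)c32)cc1`: 96 nM

Compound 3, at 96 nM, cannot be separated from the other two compounds. The step to it from the 4-fluorophenyl analogue is a 1.1-fold higher number from compound 2 to compound 3 (0.05 log units; within the scatter), and the step from the 6-fluoropyridin-3-yl analogue is a 1.5-fold lower number from compound 1 to compound 3 (0.17 log units; within the scatter). The remaining measured step, a 1.7-fold lower number from compound 1 to compound 2 (0.22 log units; within the scatter), also stays small.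

Compound 4 `COc1ccc(S(=O)(=O)N2CCc3cccc(-c4cccnc4)c32)cc1` keeps the shared core and changes only the attachment of the pyridine ring: pyridin-3-yl in place of pyridin-4-yl on an aromatic carbon. This is pyridin-3-yl in place of pyridin-4-yl on an aromatic carbon. Going by the values given here, no measured pair isolates this exact change, so the evidence is indirect. All three aryl exchanges seen so far remain within the scatter, and none suggests a direction for this one. No step beyond the scatter is therefore expected in this assay.

The estimated step is a 1.0-fold higher number from compound 3 to compound 4 (0.02 log units; within the scatter).

For compound 4 the expected value is 100 nM, with an estimated range of 45 nM to 220 nM.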

Compound 4, half-maximal inhibitory concentration: 95.9 nM
Beside the measured number, compound 4's estimate is 1.0-fold (0.02 log units) above it, and the stated range covers the measured number.
By their numbers in this assay, from the lowest: compounds 2, 4, 3 and 1 (each within the scatter of the next).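

In this assay the exchange of pyridin-4-yl for pyridin-3-yl now has a direct reading (a 1.0-fold lower number from compound 3 to compound 4 (0.00 log units; within the scatter)), so moving the ring attachment gives no separable change at this aromatic carbon. Going by these compounds alone, the step for pyridin-3-yl in place of 4-fluorophenyl (a 1.1-fold higher number from compound 2 to compound 4 (0.05 log units; within the scatter)) joins the other aryl exchanges, and the new pair for hydrogen in place of fluoro on the pyridin-3-yl ring (a 1.5-fold lower number from compound 1 to compound 4 (0.17 log units; within the scatter)) isolates that fluoro for the first time, with no separable change either. No accompanying measurement bears on why these four aryl groups cannot be told apart here.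

From the compounds shown here alone, whether this flat picture extends to pyridin-2-yl, or to a ring carrying an aminomethyl group or a carboxylic acid, stays open. The compounds shown also leave open how a saturated ring such as morpholine would read at this position.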